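The compounds below may be only part of what the source reports. "The series", "measured", "known", "first", "only" and "open" are said of these compounds alone.

Measured in a physicochemical assay for solubility, read by HPLC, in phosphate buffer, measured as kinetic solubility, at pH 7.4; on this read-out lower numbers stand for lower solubility and higher numbers for higher solubility:
- Compound 1 `CC(=O)c1cc(-c2ccc(S(N)(=O)=O)cc2)n(-c2ccc(Cl)cc2)n1`: 86800 nM
- Compound 2 `NS(=O)(=O)c1ccc(-c2cc(C(=O)N3CC4CC4C3)nn2-c2ccc(Cl)cc2)cc1`: 36600 nM

Compound 2 holds the lower of the two numbers. Compound 3 `NS(=O)(=O)c1ccc(-c2cc(C(=O)NN3CCCCC3)nn2-c2ccc(Cl)cc2)cc1` departs from it on a carbonyl carbon, where (piperidin-1-yl)amino enters: a group of 7 heavy atoms (5 carbon, 2 nitrogen; one six-membered non-aromatic ring with 1 hetero atom) in place of a group of 6 heavy atoms (5 carbon, 1 nitrogen; one three-membered non-aromatic ring of carbon only, one five-membered non-aromatic ring with 1 hetero atom), on a carbonyl carbon. Among the compounds with values here, the only measured step that bears on this is a 2.4-fold lower number from compound 1 to compound 2 (0.38 log units; beyond the scatter), a modest change at the same carbonyl carbon. It shows no direction for this exchange, so no step beyond the scatter is expected in this assay. The expected step is a 1.3-fold lower number from compound 2 to compound 3 (0.12 log units; within the scatter). For compound 3 the estimated value is 28000 nM, with an expected range of 9000 nM to 80000 nM.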

Compound 3, solubility: 53700 nM
Estimate against measurement, compound 3: 1.9-fold (0.28 log units) below; the range from low to high includes it.
By their numbers in this assay, from the lowest: compounds 2, 3 and 1 (each within the scatter of the next, the first and the last beyond it).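

In this assay the exchange on the carbonyl carbon gives a 1.5-fold higher number from compound 2 to compound 3 (0.17 log units; within the scatter) and stays within the scatter, and (piperidin-1-yl)amino in place of methyl gives a 1.6-fold lower number from compound 1 to compound 3 (0.21 log units; within the scatter) and also stays within it. At this position, then, a group with a hydrogen-bond donor leaves the number within the scatter of both compound 1 and compound 2, although a 2.4-fold lower number from compound 1 to compound 2 (0.38 log units; beyond the scatter) lies beyond it. Nothing at hand explains these numbers.

Going by these compounds, whether an open-chain group such as dimethylamino, or a carboxylic acid, on this carbonyl carbon would give a step beyond the scatter remains open.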